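The source may report more compounds than this note shows. Statements on the series, on what has been measured and on what is new or still open speak of the compounds shown alone.

- compound 1 `CC(=O)SCCC(CCCCC(=O)O)SC(C)=O`: 9.89%
- compound 2 `O=C(CCCCC(S)CCS)Nc1cccc(Cl)c1`: 7.2%
- compound 3 `O=C(CCCCC(S)CCS)Nc1ccc([N+](=O)[O-])cc1`: 4.64%

These values come from a functional assay on NCI-H460 cells (Homo sapiens) for inhibition, read by MTT assay, with a stated time of 24 h, tested at 1 ug/mL; a higher number here means more inhibition of growth at the concentration tested, a lower number less inhibition of growth. Compound 1 lies within the scatter of both compound 2 and compound 3, so the three cannot be separated on these numbers.

Compound 4 `CC(=O)SCCC(CCCCC(=O)Nc1cccc(Cl)c1)SC(C)=O` has (3-chlorophenyl)amino in place of hydroxy on a carbonyl carbon of compound 1: (3-chlorophenyl)amino in place of hydroxy on a carbonyl carbon. Compound 2 also carries (3-chlorophenyl)amino and gives 7.2%, so no step beyond the scatter is expected in this assay.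

The expected change is small, with no firm direction: the estimated a number 0.9 percentage points lower from compound 1 to compound 4 (within the scatter) stays within the scatter. For compound 4 the estimated value is 9%, with an expected range of 2% to 22%.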

Compound 4, percent growth inhibition at one concentration: 0.31%
The estimate for compound 4 lay 8.7 percentage points above the measured number, outside the stated range (below it).
By their numbers in this assay, from the lowest: compounds 4, 3, 2 and 1 (each within the scatter of the next).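

The first pair differing in one place gives in this assay a number 9.6 percentage points lower from compound 1 to compound 4 (within the scatter) and so does not separate the two compounds. On a carbonyl carbon whose other neighbour is a saturated chain carbon, (3-chlorophenyl)amino in place of hydroxy therefore produces no step beyond the scatter. No evidence bears on this result.

From the compounds shown here alone, whether an unsubstituted amino group or a longer chain on the same carbonyl carbon would give a step beyond the scatter remains open. Also open, going by these compounds, is how this pair compares at any other concentration.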